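A few compounds are considered here, and "the series" means these few. Any claim that something is new, unique, unknown or untested is made for them only; others in the source may bear on it.

Working notes on the series.

Compound 1 `CCCCc1cn(C(c2ccccc2)c2cc3cc(Br)ccc3nc2OC)nn1` has been run in an ADME assay on SK-OV-3 cells (Homo sapiens) for cytotoxicity, read by sulforhodamine B assay, with a stated time of 48 h, tested at 10 uM (on this read-out higher numbers stand for more inhibition at the one concentration tested (going by the name of the read-out) and lower numbers for less inhibition), and gives 11.1%. Compound 2 `CCCc1cn(C(c2ccccc2)c2cc3cc(Br)ccc3nc2OC)nn1` in this assay gives 11.2%; the step of a number 0.1 percentage points higher from compound 1 to compound 2 (within the scatter) leaves the two numbers indistinguishable, so compound 1 sits with compound 2 at the low end of the read-out and nothing separates them.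

Compound 3 `COc1nc2ccc(Br)cc2cc1C(c1ccccc1)n1cc(-c2cccc(F)c2)nn1` is the next member. The change from compound 1 is 3-fluorophenyl in place of butyl on an aromatic carbon.

Going by the values given here, the only measured step, a number 0.1 percentage points higher from compound 1 to compound 2 (within the scatter), shortens the chain at the same position of the five-membered ring and does not move the read-out. Among the compounds with values here, it bears on the new step only in that the same position is varied, but here a ring replaces a chain, which no measured pair covers. With both measured numbers lying at the low end and the one variation at this position flat, the expectation is for no step beyond the scatter, while the larger, untested nature of the group leaves the range wide toward higher inhibition. The estimated step of a number 3.9 percentage points higher from compound 1 to compound 3 (within the scatter) is expected to stay small. For compound 3 the estimate in this assay is 15%, within 0% to 40%.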

Compound 3, a percentage reported as inhibition, at one concentration (the size of the read-out at that concentration, not a potency): 12.7%
For compound 3 the middle estimate is 2.3 percentage points above the measured one; the measured number falls inside the stated range.
By their numbers in this assay, from the lowest: compounds 1, 2 and 3 (each within the scatter of the next).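

In this assay, 3-fluorophenyl in place of butyl gives a number 1.6 percentage points higher from compound 1 to compound 3 (within the scatter), and 3-fluorophenyl in place of propyl gives a number 1.5 percentage points higher from compound 2 to compound 3 (within the scatter). The earlier pair covered only a change of chain length, whereas these steps show that an aromatic ring of carbon only, bearing fluorine, can stand at this aromatic carbon of the five-membered ring without separating compound 3 from compound 1 or compound 2 on this read-out. No measurement bears on why the read-out stays flat across these three groups at this position.

The compounds shown do not tell whether this flatness holds for groups of another kind at the same carbon, such as an aminomethyl group, a carboxylic acid or a hydroxymethyl group, all of which differ from butyl, propyl and 3-fluorophenyl. They also leave open whether unsubstituted phenyl, or a phenyl ring with fluorine at another ring carbon, would read the same as 3-fluorophenyl, and whether any change at this carbon can lift the read-out beyond the scatter.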